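Diethylamino for dimethylamino on a longer chain and a second core

The source may hold more compounds than are shown below. What is called first, only, known or untested is meant among the compounds shown, and "the series" means these compounds.

The series comprises compound 1 `CN(C)CCn1c(N)c(-c2nc3ccccc3[nH]2)c2nc(C#N)c(C#N)nc21`, compound 2 `CCN(CC)CCn1c(N)c(-c2nc3ccccc3[nH]2)c2nc(C#N)c(C#N)nc21` and compound 3 `CN(C)CCCCn1c(N)c(-c2nc3ccccc3n2C)c2nc(C#N)c(C#N)nc21`. In a functional assay on K562 cells (Homo sapiens) for antiproliferative activity, read by MTT assay, with a stated time of 48 h (on this read-out higher numbers stand for weaker inhibition and lower numbers for stronger inhibition), compound 1 gives 6340 nM, compound 2 gives 2490 nM and compound 3 gives 1450 nM. Compound 2 differs from compound 1 by diethylamino in place of dimethylamino on a saturated chain carbon, two bonds along the chain from an aromatic nitrogen, and this change made the step of a 2.5-fold lower number from compound 1 to compound 2 (0.41 log units; beyond the scatter). The difference between the core of compound 3 and the core of compound 1 is not broken down here; their values show compound 3 with the lower number. Compound 4 `CCN(CC)CCCCn1c(N)c(-c2nc3ccccc3n2C)c2nc(C#N)c(C#N)nc21` has not been measured in this assay. It differs from compound 3 by diethylamino in place of dimethylamino on a saturated chain carbon, four bonds along the chain from an aromatic nitrogen, the same kind of change as that from compound 1 to compound 2, though here the place is four bonds along the chain from the aromatic nitrogen rather than two, and the core is that of compound 3. Because compound 2 gave 2490 nM against compound 1 at 6340 nM, a step of similar direction, estimated as a 2.1-fold lower number from compound 3 to compound 4 (0.32 log units; beyond the scatter), is expected from compound 3 to compound 4, with less confidence given the different place and core. Compound 4 is therefore estimated at 700 nM, expected to lie between 300 nM and 1600 nM.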

Compound 4, half-maximal inhibitory concentration: 1010 nM
The estimate for compound 4 lay 1.4-fold (0.16 log units) below the measured number; the range from low to high includes it.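

In this assay, diethylamino in place of dimethylamino on the core of compound 3, four bonds along the chain from an aromatic nitrogen, gave a 1.4-fold lower number from compound 3 to compound 4 (0.16 log units; within the scatter). Set beside the earlier step, the change cannot be told apart on the two cores: the same change on two cores in this assay, a 2.5-fold lower number (0.41 log units; beyond the scatter) from compound 1 to compound 2 and a 1.4-fold lower number (0.16 log units; within the scatter) from compound 3 to compound 4, 1.8-fold (0.25 log units) apart, within the scatter of two such steps. This shows that the two steps are compatible with one another, but it does not show that the change carries over with a fixed size: only the earlier step lies beyond the scatter, and the core and the place of the change differ together, so neither can be weighed alone.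

The compounds shown leave open how the step reads when only the core differs, with the chain of compound 1 placed on the core of compound 3. They also leave open whether a cyclic amine such as morpholine or piperidine, or a longer chain, would follow the same course at the end of the chain.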